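This account rests on a few compounds, and the source may have more. Where it says the series, first, only, none or still open, it means among the compounds named here.

Measured in an ADME assay on HEK293 cells (Homo sapiens) for cytotoxicity, read by luminescence, with a stated time of 72 h; a higher number here means that more compound is needed for the effect, a lower number that less compound is needed:

Compound 1 `CCOC(=O)c1c(-c2cccc(C(F)(F)F)c2)[nH]c2cc(OC)ccc2c1=O`: > 22000 nM (a limit)
Compound 2 `CCOC(=O)c1c(-c2cccc(Br)c2)[nH]c2cc(OC)ccc2c1=O`: > 22000 nM (a limit)

Compound 2 stands at > 22000 nM, which is a limit and not a number. Among the compounds with values here, no actual value is known for either compound so far: the limit of > 22000 nM in this assay, at which 2 of the 2 values shown sit.

The next change gives compound 3 `CCOC(=O)c1c(-c2cccc(NC(C)=O)c2)[nH]c2cc(OC)ccc2c1=O`, with acetamido in place of bromo on an aromatic carbon.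

Within the data shown here, only one measured step bears on this, a step that the two limits leave unreadable from compound 1 to compound 2, and it swaps a different pair of groups at that aromatic carbon. It offers no size to carry over, so no step beyond the usual scatter is expected in this assay. The expected change is a step that the limit leaves unreadable from compound 2 to compound 3, and it is only a weakly supported estimate.

For compound 3 the estimated value is 25000 nM, with an expected range from 12000 nM to 50000 nM.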

Compound 3, half-maximal effective concentration: > 22000 nM
Compound 3 ended at the assay's limit; the forecaster's own chance of this, stated with the estimate: 80%; the middle value is on the limit's open side.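

In this assay, within the data shown here, compound 3 gives > 22000 nM, a limit and not a number, so no step from compound 1 or compound 2 to compound 3 can be read. What stays open is the actual concentration each of the three compounds needs for the effect, and whether they differ at all: the limit of > 22000 nM in this assay, at which 3 of the 3 values shown sit.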